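Ester to methyl ketone on a shared core

This account rests on a few compounds, and the source may have more. Where it says the series, first, only, none or still open, it means among the compounds named here.

Measured so far:
Compound 1 `C=C(C)[C@@H]1CC=C(Cn2cc(COc3ccccc3C3NC(=O)NC(C)=C3C(=O)OCC)nn2)CC1` gives > 100000 nM in a functional assay on PC-3 cells (Homo sapiens) for inhibition, read by sulforhodamine B assay, with a stated time of 48 h (on this read-out higher numbers stand for weaker inhibition of growth and lower numbers for stronger inhibition of growth), which is a limit of the assay rather than a number.
Compound 2 `C=C(C)[C@@H]1CC=C(Cn2cc(COc3ccc(C4NC(=O)NC(C)=C4C(=O)OCC)cc3OC)nn2)CC1` gives 54400 nM in this assay.

For the measured compounds named here, compound 2 therefore holds the only real number here; the other value is a limit, as the limit of > 100000 nM in this assay, at which 1 of the 2 values shown sits, records. Compound 3 `C=C(C)[C@@H]1CC=C(Cn2cc(COc3ccc(C4NC(=O)NC(C)=C4C(C)=O)cc3OC)nn2)CC1` has not yet been measured. It differs from compound 2 by methyl in place of ethoxy on a carbonyl carbon. Going by the values given here, no measured pair in this set shares that change, so no step size can be read off. The change is expected to move the number no further than the usual scatter, a 1.1-fold lower number from compound 2 to compound 3 (0.04 log units; within the scatter). Compound 3 is estimated at 50000 nM, between 20000 nM and 150000 nM.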

Compound 3, concentration for total growth inhibition: 85700 nM
For compound 3 the middle estimate is 1.7-fold (0.23 log units) below the measured one; the range from low to high includes it.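

In this assay the change from ethoxycarbonyl to acetyl gives a 1.6-fold higher number from compound 2 to compound 3 (0.20 log units; within the scatter) and so leaves the two compounds indistinguishable. At this carbonyl carbon, then, methyl can take the place of ethoxy without a change beyond the usual scatter. Both numbers still lie at the weak end of this read-out, not far from the highest value it records: the limit of > 100000 nM in this assay, at which 1 of the 3 values shown sits.

As far as these compounds go, whether an amine, a carboxylic acid or a longer chain on this carbonyl carbon would move the number beyond the scatter stays open. One pair also cannot show whether the same swap would behave alike on another core.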